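Bromo for chloro on the pendant phenyl of compound 3

This account rests on a few compounds, and the source may have more. Where it says the series, first, only, none or still open, it means among the compounds named here.

Measured in a functional assay on the whole organism (strain Wistar albino) for inhibition, with Rattus norvegicus as the target, read by paw edema, with a stated time of 5 h, at a dose of 100 mg/kg by the oral route; a higher number here means more inhibition at the dose given (going by the name of the read-out), a lower number less inhibition:
compound 1 `Cc1ccc2c(Cc3nn4cc(-c5ccc(Br)cc5)nc4s3)coc2c1` gives 22.5%
compound 2 `Cc1ccc2c(Cc3nn4c(C=O)c(-c5ccc(Br)cc5)nc4s3)coc2c1` gives 12.4%
compound 3 `Cc1ccc2c(Cc3nn4c(CO)c(-c5ccc(Cl)cc5)nc4s3)coc2c1` gives 58.9%

Compound 3 stands highest of the three, beyond the scatter from both compound 1 and compound 2. Going by the values given here, the only measured step, a number 10.1 percentage points lower from compound 1 to compound 2 (beyond the scatter), concerns a formyl group on the shared core and does not touch the pendant phenyl. Compound 4 `Cc1ccc2c(Cc3nn4c(CO)c(-c5ccc(Br)cc5)nc4s3)coc2c1` differs from compound 3 by bromo in place of chloro on an aromatic carbon. Among the compounds with values here, no measured pair isolates this swap: compound 1 and compound 2 carry bromo but differ from compound 3 in other places too, so their values cannot be read as a halogen step. Within the data shown here, with no bearing step, no change beyond the scatter is expected; the expected step is a number 3.9 percentage points lower from compound 3 to compound 4 (within the scatter). Compound 4 is therefore estimated at 55%, in the range 40% to 70%.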

Compound 4, a percentage reported as inhibition, in the whole organism at one dose (the size of the read-out at that dose, not a potency): 47.3%
Compound 4: the middle estimate sits 7.7 percentage points above what was measured, and the stated range covers the measured number.
By their numbers in this assay, from the lowest: compound 2; then compound 1; then compound 4; then compound 3.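

The change from 4-chlorophenyl to 4-bromophenyl can now be read directly in this assay: the swap gives a number 11.6 percentage points lower from compound 3 to compound 4 (beyond the scatter) and so the two halogens are not interchangeable in this pair. With bromo held constant, hydroxymethyl on the aromatic carbon of the shared core gives a number 34.9 percentage points higher from compound 2 to compound 4 (beyond the scatter) against formyl and a number 24.8 percentage points higher from compound 1 to compound 4 (beyond the scatter) against hydrogen, so the larger gain belongs to hydroxymethyl rather than to the halogen. Nothing available explains these differences.

As far as these compounds go, whether fluoro or methoxy would hold up on the pendant phenyl remains open. So does whether an amine or a carboxylic acid could replace hydroxymethyl on the core.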